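The source may hold more compounds than are shown below. What is called first, only, known or untested is meant among the compounds shown, and "the series" means these compounds.

Measured in a functional assay on RAW264.7 cells (Mus musculus) for inhibition; on this read-out lower numbers stand for stronger inhibition and higher numbers for weaker inhibition:
Compound 1 `CC1=C(c2ccc(C)c(C)c2)S(=O)(=O)N(Cc2ccc(C(=O)N3CCCCC3)cc2)C1=O`: 16500 nM
Compound 2 `CC(C)(C)OC(=O)N(Cc1ccco1)C(=O)c1ccc(CN2C(=O)c3ccccc3C2=O)cc1`: 3450 nM
Compound 3 `O=C(NCc1ccco1)c1ccc(CN2C(=O)c3ccccc3C2=O)cc1`: 56000 nM

Compound 2 gives the lowest number of the three, 3450 nM, and so the strongest inhibition among them. Compound 4 `CC(C)(C)OC(=O)N(Cc1ccco1)C(=O)c1ccc(Cn2c(=O)c3ccccc3[s+]2[O-])cc1` differs from compound 2 in one place: a group of 11 heavy atoms (7 carbon, 1 nitrogen, 2 oxygen, 1 sulfur; one five-membered aromatic ring with 2 hetero atoms, one six-membered aromatic ring of carbon only) in place of a group of 11 heavy atoms (8 carbon, 1 nitrogen, 2 oxygen; one five-membered non-aromatic ring with 1 hetero atom, one six-membered aromatic ring of carbon only), on a saturated chain carbon bound to an aromatic carbon. Within the data shown here, no measured step covers this exchange. The only one available, a 16-fold higher number from compound 2 to compound 3 (1.21 log units; beyond the scatter), puts hydrogen in place of tert-butoxycarbonyl on an amide-type nitrogen, and compound 4 keeps that group. That step bears only indirectly, showing that a single change can move the number far. No step beyond the scatter is therefore expected in this assay, though with wide uncertainty. The expected outcome is a 1.2-fold lower number from compound 2 to compound 4 (0.06 log units; within the scatter). For compound 4 the estimated value is 3000 nM, with an expected range of 800 nM to 12000 nM.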

Compound 4, half-maximal inhibitory concentration: 68000 nM
Estimate against measurement, compound 4: 23-fold (1.36 log units) below; the whole stated range lies below it.
By their numbers in this assay, from the lowest: compound 2; then compound 1; then compounds 3 and 4 (each within the scatter of the next).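

In this assay, the exchange on the saturated chain carbon bound to an aromatic carbon gives a 20-fold higher number from compound 2 to compound 4 (1.29 log units; beyond the scatter), so this place, and not only the amide-type nitrogen, can move the number far. The two groups have the same count of heavy atoms, so that count alone does not hold the number here. No available evidence bears on the reason for this step. The compounds shown leave open whether the same exchange would matter with the amide hydrogen in place of tert-butoxycarbonyl. They also leave open how a simple amine or a carboxylic acid would fare at this place.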